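The source may hold more compounds than are shown below. What is called first, only, known or untested is meant among the compounds shown, and "the series" means these compounds.

Measured set in a functional assay on MT2 cells (Homo sapiens) for cytotoxicity, read by MTT assay; on this read-out lower numbers stand for higher toxicity in this test and higher numbers for lower toxicity in this test:
Compound 1 `CC(C)=CCOc1cc(Nc2nccs2)ccc1Cl` gives 26000 nM.
Compound 2 `Clc1ccc(Nc2nccs2)cc1OCc1nccs1` gives 20000 nM.
Compound 3 `CC(C)=CCOc1cc(Nc2nccc(C)n2)ccc1Cl` gives only a limit of the assay, < 200 nM.

For the measured compounds named here, compound 3 thus sits at the limit of < 200 nM in this assay, at which 1 of the 3 values shown sits, the one member of the set at that limit. Of the two measured steps, a 1.3-fold lower number from compound 1 to compound 2 (0.11 log units; within the scatter) stays within the scatter, whereas an at least 130-fold lower number from compound 1 to compound 3 (2.11 log units; beyond the scatter) is large.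

Compound 4 `COc1ccnc(Nc2ccc(Cl)c(OCC=C(C)C)c2)n1` differs from compound 3 by methoxy in place of methyl on an aromatic carbon. Going by the values given here, no measured step touches this part of the molecule; the large step of an at least 130-fold lower number from compound 1 to compound 3 (2.11 log units; beyond the scatter) changes a different part, which compound 4 keeps as in compound 3. The expected step is therefore a step that the limit leaves unreadable from compound 3 to compound 4, none beyond the scatter, and another limit reading is plausible. Compound 4 is estimated at 150 nM, with a range of 40 nM to 600 nM.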

Compound 4, half-maximal cytotoxic concentration: 9000 nM
For compound 4 the middle estimate is 60-fold (1.78 log units) below the measured one, outside the stated range (above it).
By their numbers in this assay, from the lowest: compound 4; then compounds 2 and 1 (each within the scatter of the next). At a limit, below all of these: compound 3.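

At this position, an aromatic carbon next to the ring nitrogen, methoxy in place of methyl gives an at least 45-fold higher number from compound 3 to compound 4 (1.65 log units; beyond the scatter) in this assay, so the substituent here matters as much as the ring change did. The six-membered aromatic ring alone therefore does not fix the low number seen for compound 3. Compound 3 gives a limit, not a number, so the step has no upper bound: the limit of < 200 nM in this assay, at which 1 of the 4 values shown sits.

On these data alone, whether the step goes with the oxygen of methoxy or with the longer substituent stays open. An ethyl group or an amine at this carbon would separate the two.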